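The source may report more compounds than this note shows. Statements on the series, on what has been measured and on what is new or still open speak of the compounds shown alone.

Measured compounds:
- compound 1 `CN(CC1CC1)CC1(O)CCN(CCCc2c[nH]c3ccc(-n4cnnc4)cc23)CC1`: 1.35 nM
- compound 2 `OC1(CNCc2ccccc2)CCN(CCCc2c[nH]c3ccc(-n4cnnc4)cc23)CC1`: 0.45 nM
- compound 3 `CC(C)(C)OC(=O)NCC1(O)CCN(CCCc2c[nH]c3ccc(-n4cnnc4)cc23)CC1`: 21 nM

In an assay on CHO cells with 5-hydroxytryptamine receptor 1D (Homo sapiens) as the target (on this read-out higher numbers stand for weaker inhibition and lower numbers for stronger inhibition), compound 3 stands at the highest number of the three, a step of a 16-fold higher number from compound 1 to compound 3 (1.19 log units; beyond the scatter) above compound 1 and of a 47-fold higher number from compound 2 to compound 3 (1.67 log units; beyond the scatter) above compound 2. Both measured steps touch the same position, the substituent on the saturated chain carbon bound to the saturated ring carbon of the shared core, and both say that the (tert-butoxycarbonyl)amino group is the weakest of the three variants tried there.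

Compound 4 `CC1(C)CCCN(CC2(O)CCN(CCCc3c[nH]c4ccc(-n5cnnc5)cc34)CC2)C1` has not yet been measured. Its change from compound 3 is 3,3-dimethylpiperidin-1-yl in place of (tert-butoxycarbonyl)amino on a saturated chain carbon bound to a saturated ring carbon. The group that enters is closer in kind to the (cyclopropylmethyl)(methyl)amino group of compound 1 than to the group it replaces, in that the nitrogen again carries saturated carbons only and no carbonyl.

The two steps that bear on this change, a 16-fold higher number from compound 1 to compound 3 (1.19 log units; beyond the scatter) and a 47-fold higher number from compound 2 to compound 3 (1.67 log units; beyond the scatter), were both large, and both ran in the direction of a higher number when the (tert-butoxycarbonyl)amino group was introduced. Undoing it in compound 4 is therefore expected to give a large step back to a lower number in this assay, on the order of a 14-fold lower number from compound 3 to compound 4 (1.15 log units; beyond the scatter).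

The number for compound 4 is estimated at 1.5 nM, with a range of 0.4 nM to 6 nM.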

Compound 4, half-maximal inhibitory concentration: 0.65 nM
Estimate against measurement, compound 4: 2.3-fold (0.36 log units) above; the range from low to high includes it.
By their numbers in this assay, from the lowest: compounds 2 and 4 (each within the scatter of the next); then compound 1; then compound 3.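

In this assay, the step of a 32-fold lower number from compound 3 to compound 4 (1.51 log units; beyond the scatter) swaps groups with the same count of heavy atoms, so that count alone does not set the number at this position; what differs is that the entering 3,3-dimethylpiperidin-1-yl group has a ring and no carbonyl or hydrogen-bond donor. The step of a 1.4-fold higher number from compound 2 to compound 4 (0.16 log units; within the scatter) lies within the scatter, so benzylamino, which has a hydrogen on its nitrogen, and 3,3-dimethylpiperidin-1-yl, which has no hydrogen-bond donor, cannot be told apart here, and a donor in this group is not required for a number this low. The step of a 2.1-fold lower number from compound 1 to compound 4 (0.32 log units; beyond the scatter) is modest but beyond the scatter, and this single pair gives the piperidine a small edge over the open-chain (cyclopropylmethyl)(methyl)amino group.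

The compounds shown leave open whether a morpholin-4-yl group, a free primary amino group or an acetylamino group at this place would track compound 4 or compound 3, and so whether the high number of compound 3 goes with the carbonyl or with the tert-butyl part. Nothing shown gives a measured reason for any of these steps.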